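A few compounds are considered here, and "the series" means these few. Any claim that something is new, unique, unknown or untested is made for them only; others in the source may bear on it.

Compound 1 `COc1ccc(-c2cc(/C=C/C(=O)c3ccc(N)cc3)[nH]n2)cc1` is tested in a functional assay on NCI-H23 cells (Homo sapiens) for cytotoxicity, read by sulforhodamine B assay, with a stated time of 48 h, tested at 1 uM (a lower number here means a stronger effect, a higher number a weaker effect of the compound at the concentration tested), where compound 1 gives 93%. Going by the values given here, the only other compound measured there, compound 2 `COc1cc(-c2cc(/C=C/C(=O)c3ccc(F)c(F)c3)[nH]n2)cc(OC)c1OC`, gives 90%, and the two numbers lie within the usual scatter of each other, so neither can be called the stronger. Compound 3 `COc1ccc(-c2cc(/C=C/C(=O)c3ccc(N)cc3)[nH]n2)cc1OC` is not yet measured; it differs from compound 1 by methoxy in place of hydrogen on an aromatic carbon. Among the compounds with values here, with no measured step to rely on, a step from compound 1 to compound 3 of a number 3 percentage points lower from compound 1 to compound 3 (within the scatter) is expected, which is none beyond the scatter. Compound 3 is therefore estimated at 90%, between 75% and 100%.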

Compound 3, a percentage reported as activity, at one concentration (the size of the read-out at that concentration, not a potency): 99%
Compound 3: the middle estimate sits 9 percentage points below what was measured; low and high end bracket the measured number.
By their numbers in this assay, from the lowest: compounds 2, 1 and 3 (each within the scatter of the next).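

Going by these compounds alone, the step of a number 6 percentage points higher from compound 1 to compound 3 (within the scatter) is the first measured one-place change in this assay. It shows that at this aromatic carbon, ortho to a methoxy group, compound 1 and compound 3 cannot be told apart, so this methoxy in place of hydrogen gives no sign of a stronger effect at the concentration tested. Nothing available offers an explanation for this result. From the compounds shown here alone, whether a hydroxyl group, a fluorine atom or an amine on this same carbon would give a clearly lower number remains open. So does the outcome for a longer chain such as ethoxy.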